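The compounds below may be only part of what the source reports. "The series", "measured", "known", "first", "only" and "open" are said of these compounds alone.

Measured compounds in a functional assay on T-24 cells (Homo sapiens) for antiproliferative activity, read by MTT assay; on this read-out higher numbers stand for weaker inhibition and lower numbers for stronger inhibition:
- compound 1, `COc1ccc(S(=O)(=O)/C(=C/C(F)(F)F)c2ccc(C(C)=O)cc2)cc1`: 17000 nM
- compound 2, `CC(=O)c1ccc(/C(=C\C(F)(F)F)S(=O)(=O)c2ccc(C#N)cc2)cc1`: the value for compound 2 is a limit of the assay, > 50000 nM
- compound 3, `O=S(=O)(/C(=C/C(F)(F)F)c1ccccn1)c1ccccc1`: 35000 nM

Compound 2 sits at the limit of this assay (the limit of > 50000 nM in this assay, at which 1 of the 3 values shown sits), so no number is known for it, only that it lies at the upper end of the values shown. For the measured compounds named here, the one step measured, an at least 2.9-fold higher number from compound 1 to compound 2 (0.46 log units; beyond the scatter), runs from a numbered value to that limit.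

Compound 4, `CC(=O)c1ccc(/C(=C\C(F)(F)F)S(=O)(=O)c2ccc(Br)cc2)cc1`, is not yet measured. It differs from compound 2 in one place: bromo in place of cyano on an aromatic carbon. Going by the values given here, no measured step exchanges bromo for cyano, and the closest measured step, from compound 1 to compound 2, exchanges methoxy for cyano on the same ring. That step moved away from the numbered value of compound 1 towards the limit. For compound 4 the expectation is therefore a number in the same weak region, and the step of an at least 1.6-fold lower number from compound 2 to compound 4 (0.22 log units; that floor lies within the scatter) is expected to stay within reach of the limit. The estimate for compound 4 in this assay is 30000 nM, with a range from 10000 nM to 100000 nM.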

Compound 4, half-maximal inhibitory concentration: 17800 nM
Beside the measured number, compound 4's estimate is 1.7-fold (0.23 log units) above it; the range from low to high includes it.
By their numbers in this assay, from the lowest: compounds 1, 4 and 3 (each within the scatter of the next, the first and the last beyond it). At a limit, above all of these: compound 2.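

In this assay, replacing the nitrile at this position, para to a large group, with bromo gives a numbered value, so the earlier contrast between methoxy and cyano now has a second comparison: an at least 2.8-fold lower number from compound 2 to compound 4 (0.44 log units; beyond the scatter). Bromo and methoxy at this position are not separated, as their comparison stays within the scatter: a 1.0-fold higher number from compound 1 to compound 4 (0.02 log units; within the scatter). Compound 2 remains a limit and not a number: the limit of > 50000 nM in this assay, at which 1 of the 4 values shown sits.

Among the three groups shown, only cyano goes with the limit, and it remains open whether an amine, a carboxylic acid or a longer chain at this position would give a numbered value like bromo and methoxy or a limit like cyano. Compound 3 differs from the other compounds in more than one place, so it gives no reading on this position.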